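Swapping an Acid for a Tetrazole on a Second Core

A few compounds are considered here, and "the series" means these few. Any claim that something is new, unique, unknown or untested is made for them only; others in the source may bear on it.

Of the compounds shown here, three have been measured so far. Compound 1 `O=C(O)CC1CCCC1Cc1ccc(OCc2ccc3ccccc3n2)cc1` gives 100 nM in an assay on membranes from lung (Cavia porcellus) for binding affinity to cysteinyl leukotriene receptor (Homo sapiens); on this read-out higher numbers stand for weaker inhibition and lower numbers for stronger inhibition. Compound 2 `CC(CCCC(=O)O)c1cccc(OCc2ccc3ccccc3n2)c1` gives 90 nM in this assay, and compound 3 `CC(CCCc1nnn[nH]1)c1cccc(OCc2ccc3ccccc3n2)c1` gives 31 nM there. The difference between the cores of compound 1 and compound 2 is not broken down here; their two values lie within the usual scatter of each other. Compound 3 differs from compound 2 in one place, (1H-tetrazol-5-yl in place of carboxy on a saturated chain carbon, four bonds along the chain from an aromatic carbon), and that change produced a 2.9-fold lower number from compound 2 to compound 3 (0.46 log units; beyond the scatter). Compound 4 `c1ccc2nc(COc3ccc(CC4CCCC4Cc4nnn[nH]4)cc3)ccc2c1` differs from compound 1 by the same kind of change, (1H-tetrazol-5-yl in place of carboxy on a saturated chain carbon bound to a saturated ring carbon); the surroundings differ, since in compound 2 the saturated chain carbon is four bonds along the chain from an aromatic carbon, while in compound 1 it is bound to a saturated ring carbon. The change occurs only twice among these compounds, so the single measured step is the only guide. The step from compound 1 to compound 4 is expected to be a 2.9-fold lower number from compound 1 to compound 4 (0.46 log units; beyond the scatter), resting on a 2.9-fold lower number from compound 2 to compound 3 (0.46 log units; beyond the scatter). Compound 4 is therefore estimated to give about 35 nM, between 15 nM and 80 nM.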

Compound 4, inhibition constant: 15 nM
Beside the measured number, compound 4's estimate is 2.3-fold (0.37 log units) above it; the measured number falls inside the stated range.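

On the core of compound 1, putting 1H-tetrazol-5-yl in place of carboxy gave a 6.7-fold lower number from compound 1 to compound 4 (0.82 log units; beyond the scatter) in this assay, so the number fell on both cores when this change was made. The two steps look different in size, but they cannot be told apart: the same change on two cores in this assay, a 2.9-fold lower number (0.46 log units; beyond the scatter) from compound 2 to compound 3 and a 6.7-fold lower number (0.82 log units; beyond the scatter) from compound 1 to compound 4, 2.3-fold (0.36 log units) apart, within the scatter of two such steps

Within the data shown here, this shows that the change carried over from one core to the other with a similar effect, and it gives no sign that the core of compound 1 responds more strongly; it does not show that the same would hold on every core, since only two pairs of compounds support it.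

Going by these compounds, every compound here ends in either carboxy or 1H-tetrazol-5-yl, so it remains open how a primary amide or a sulfonamide in the same place would behave. Also open, on these data alone, is whether a longer chain carrying the 1H-tetrazol-5-yl group would keep the lower numbers seen for compound 3 and compound 4.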